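Fluoro added to the phenylsulfanyl ring of compound 3

The compounds below may be only part of what the source reports. "The series", "measured", "known", "first", "only" and "open" are said of these compounds alone.

The series shares one core, carried by compound 1 `Cn1cnc2c(Sc3ccc(F)cc3)ncnc21`, compound 2 `Cn1c(-c2ccccc2)nc2c(Sc3ccc(F)cc3)ncnc21` and compound 3 `CSc1ccc(-c2nc3c(Sc4ccccc4)ncnc3n2C)cc1`. In an assay on isolated protein for inhibition of RAC-alpha serine/threonine-protein kinase (Homo sapiens), tested at 30 uM (a lower number here means less inhibition, a higher number more inhibition at the concentration tested (going by the name of the read-out)), compound 1 gives 0%, compound 2 gives 29% and compound 3 gives 5%. For the measured compounds named here, the one step measured so far, a number 29 percentage points higher from compound 1 to compound 2 (beyond the scatter), concerns the group on the core and not the phenylsulfanyl ring. Compound 3 stands second highest of the three numbers, within the scatter of compound 1 and beyond it only against compound 2.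

Compound 4 `CSc1ccc(-c2nc3c(Sc4ccc(F)cc4)ncnc3n2C)cc1` differs from compound 3 by fluoro in place of hydrogen on an aromatic carbon. Going by the values given here, no measured pair isolates this change: compound 1 and compound 2 already carry the fluoro, and compound 3 is the only member without it. Among the compounds with values here, the single step known says nothing about fluoro on this ring, so no shift beyond the scatter is expected; the estimated step is a number 3 percentage points higher from compound 3 to compound 4 (within the scatter). Compound 4 is therefore expected to give about 8%, in the range 0% to 25%, once measured in this assay.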

Compound 4, a percentage reported as inhibition, at one concentration (the size of the read-out at that concentration, not a potency): 0%
Beside the measured number, compound 4's estimate is 8 percentage points above it, and the stated range covers the measured number.
By their numbers in this assay, from the lowest: compounds 1, 4 and 3 (each within the scatter of the next); then compound 2.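

In this assay, for the compounds shown here, the step for fluoro in place of hydrogen on the phenylsulfanyl ring is a number 5 percentage points lower from compound 3 to compound 4 (within the scatter) and this is the first pair to isolate that change, though at numbers this low it is read against a 4-(methylsulfanyl)phenyl group only. With the fluoro held constant, methylsulfanyl on the phenyl group gives a number 29 percentage points lower from compound 2 to compound 4 (beyond the scatter) and removes the gain that came with plain phenyl, since 4-(methylsulfanyl)phenyl in place of hydrogen gives no change at the digits printed from compound 1 to compound 4 (within the scatter) as its step. Nothing available accounts for these steps.

Going by these compounds alone, still open is whether fluoro matters when the group on the core is plain phenyl, the only group here with a step beyond the scatter from compound 1. Also open, from the compounds shown here alone, is whether an amine or a carboxylic acid on that phenyl would keep the inhibition seen with compound 2, which gives 29% in this assay, or lose it as methylsulfanyl does.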